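The source may hold more compounds than are shown below. What is called first, only, known or untested is meant among the compounds shown, and "the series" means these compounds.

Measured in an ADME assay on HEp-2 cells (Homo sapiens) for cytotoxicity; on this read-out higher numbers stand for lower toxicity in this test and lower numbers for higher toxicity in this test
- compound 1 `CC(=O)NCc1ccc2c(c1)nc(Cn1c(=O)n(C(C)C)c3ccccc31)n2CCC(C)C` gives 178000 nM
- compound 2 `CC(C)CCn1c(Cn2c(=O)n(C(C)C)c3ccccc32)nc2cc(CNS(C)(=O)=O)ccc21` gives 30800 nM
- compound 3 `CC(C)CCn1c(Cn2c(=O)n(C(C)C)c3ccccc32)nc2cc(C(C)(C)N)ccc21` gives 3270 nM

Compound 3 has the lowest number of the three, and both other compounds stand above it by more than the scatter. Compound 4 `CCc1ccc2c(c1)nc(Cn1c(=O)n(C(C)C)c3ccccc31)n2CCC(C)C` keeps the shared core but carries ethyl in place of 1-amino-1-methylethyl on an aromatic carbon. The counted difference is ethyl in place of 1-amino-1-methylethyl on an aromatic carbon and no other part of the structure changes.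

Two measured steps bring in the group that compound 4 gives up. One is a 54-fold lower number from compound 1 to compound 3 (1.74 log units; beyond the scatter) and is large. The other is a 9.4-fold lower number from compound 2 to compound 3 (0.97 log units; beyond the scatter) and is modest. Among the measured compounds shown here, neither starts from ethyl, and no ethyl compound has been measured, so they are only a guide. The remaining step, a 5.8-fold lower number from compound 1 to compound 2 (0.76 log units; beyond the scatter) in size, shows that the two compounds without the 1-amino-1-methylethyl group also differ clearly from each other.

Losing that group therefore points to a higher number in this assay with a step of modest size expected. The estimate amounts to a 7.6-fold higher number from compound 3 to compound 4 (0.88 log units; beyond the scatter) as the expected change. For compound 4 the estimated value is 25000 nM with an expected range from 6000 nM to 100000 nM in this reading.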

Compound 4, half-maximal cytotoxic concentration: 18500 nM
Beside the measured number, compound 4's estimate is 1.4-fold (0.13 log units) above it; measured number inside the range.
By their numbers in this assay, from the lowest: compound 3; then compounds 4 and 2 (each within the scatter of the next); then compound 1.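

Replacing 1-amino-1-methylethyl with ethyl on this aromatic carbon gives a 5.7-fold higher number from compound 3 to compound 4 (0.75 log units; beyond the scatter) in this assay, so the low number of compound 3 goes with that group and not with the shared core alone. The ethyl compound also shows that a nitrogen-bearing group at this position is not needed for a number in this middle range: a 1.7-fold lower number from compound 2 to compound 4 (0.22 log units; within the scatter), so the ethyl group and the (methanesulfonamido)methyl group cannot be told apart in this assay. Compound 1 remains clearly separate, with a 9.6-fold lower number from compound 1 to compound 4 (0.98 log units; beyond the scatter), which makes the acetamido end of its side chain, rather than the mere presence of a longer chain with a nitrogen, the feature that goes with the highest number among these compounds.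

Nothing available here explains why these numbers differ. As far as these compounds go, it also remains open whether the low number of compound 3 follows the amine or the two methyl groups on the carbon that carries it, a question that an isopropyl group or an aminomethyl group on the same aromatic carbon could help to separate.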